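Swapping Chloro for Methoxy on a Triazole Series

This account rests on a few compounds, and the source may have more. Where it says the series, first, only, none or still open, it means among the compounds named here.

Compound 1 `CC[C@H](CCn1cncn1)c1ccc(F)cc1` gives 103 ug/mL in an ADME assay on HEp-2 cells (Homo sapiens) for cytotoxicity, read by MTT assay, with a stated time of 3 days; on this read-out lower numbers stand for higher toxicity in this test and higher numbers for lower toxicity in this test.
Compound 2 `CC[C@H](CCn1cncn1)c1ccc(Cl)cc1` gives 50.6 ug/mL in this assay.
Compound 3 `CC[C@@H](CCn1cncn1)c1ccc(Cl)cc1` gives 55.1 ug/mL in this assay.

Compound 2 has the lowest number of the three. Its step to compound 3 is a 1.1-fold higher number from compound 2 to compound 3 (0.04 log units; within the scatter), which follows from the fact that compounds 2 and 3 differ only in the configuration as drawn; its step from compound 1 is a 2.0-fold lower number from compound 1 to compound 2 (0.31 log units; beyond the scatter). Compound 4 `CC[C@H](CCn1cncn1)c1ccc(OC)cc1` differs from compound 2 by methoxy in place of chloro on an aromatic carbon. Among the measured compounds shown here, neither measured step covers this change: the only substituent step, fluoro to chloro, moved the number modestly downward, and the configuration step did not move it. A change of comparable, modest size in this assay is expected for compound 4, more likely upward, as a 1.6-fold higher number from compound 2 to compound 4 (0.20 log units; within the scatter). Compound 4 is therefore estimated at 80 ug/mL, between 40 ug/mL and 160 ug/mL.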

Compound 4, half-maximal cytotoxic concentration: 153 ug/mL
For compound 4 the middle estimate is 1.9-fold (0.28 log units) below the measured one, within the range that was stated.
By their numbers in this assay, from the lowest: compounds 2, 3, 1 and 4 (each within the scatter of the next, the first and the last beyond it).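

Methoxy in place of chloro at this position, para to a large group, gives a 3.0-fold higher number from compound 2 to compound 4 (0.48 log units; beyond the scatter) in this assay while methoxy in place of fluoro gives a 1.5-fold higher number from compound 1 to compound 4 (0.17 log units; within the scatter) in the same test. Among these three groups, then, chloro alone stands apart, and methoxy does not separate from fluoro despite its extra heavy atom and hydrogen-bond acceptor.

Going by these compounds, whether an amine or a carboxylic acid at this position would fall with chloro or with fluoro and methoxy remains open. The available evidence does not explain the new steps.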